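A few compounds are considered here, and "the series" means these few. Any claim that something is new, unique, unknown or untested is made for them only; others in the source may bear on it.

Notes on the series. Three measured compounds share one core and differ only in the aromatic ring attached to it. Compound 1 `O=C(O)Cc1sc(C(c2ccc(F)cc2)c2ccc(F)cc2)nc1-c1ccoc1` carries a furan-3-yl; in an in vitro functional assay on HEK285-7 cells for antagonist activity at prostaglandin D2 receptor 2 (Homo sapiens), read by BRET and beta-arrestin recruitment (on this read-out lower numbers stand for smaller maximal responses and higher numbers for larger maximal responses), compound 1 gives 80%. Compound 2 `O=C(O)Cc1sc(C(c2ccc(F)cc2)c2ccc(F)cc2)nc1-c1cc(F)nc(F)c1` carries a 2,6-difluoropyridin-4-yl; in this assay compound 2 gives 80%. Compound 3 `O=C(O)Cc1sc(C(c2ccc(F)cc2)c2ccc(F)cc2)nc1-c1cn[nH]c1` carries a 1H-pyrazol-4-yl; in this assay compound 3 gives 80%. The steps between them are no change at the digits printed from compound 1 to compound 2 (within the scatter), no change at the digits printed from compound 1 to compound 3 (within the scatter) and no change at the digits printed from compound 2 to compound 3 (within the scatter). Compound 3 thus stands level with compounds 1 and 2 at the digits shown, compound 1 nearest and compound 2 furthest, with no step beyond the scatter in either direction.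

Compound 4 `O=C(O)Cc1sc(C(c2ccc(F)cc2)c2ccc(F)cc2)nc1-c1ccnc(Cl)c1` has not yet been measured. The change from compound 3 is 2-chloropyridin-4-yl in place of 1H-pyrazol-4-yl on an aromatic carbon. All three measured steps bear on it: each also exchanges the aromatic ring at this same position of the core, and each stayed flat within the scatter. A step of the same kind is therefore expected in this assay, none beyond the scatter, the expected step being no change at the digits printed from compound 3 to compound 4 (within the scatter). For compound 4 the estimate in this assay is 80%, with a range from 70% to 90%.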

Compound 4, largest response reached (reported as efficacy), in percent of the reference or control that the assay uses: 80%
Beside the measured number, compound 4's estimate shows no gap at the digits printed; the measured number falls inside the stated range.
By their numbers in this assay, from the lowest: compounds 1, 2, 3 and 4 (each within the scatter of the next).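

In this assay, 2-chloropyridin-4-yl in place of 1H-pyrazol-4-yl gives a flat result (no change at the digits printed from compound 3 to compound 4 (within the scatter)), so a five-membered aromatic ring with a hydrogen-bond donor can give way at this position to a six-membered aromatic ring without one, with no step beyond the scatter. Chlorine is also new at this position, and it too leaves the read-out flat, both against the fluorinated pyridine (no change at the digits printed from compound 2 to compound 4 (within the scatter)) and against the furan (no change at the digits printed from compound 1 to compound 4 (within the scatter)). Across these four compounds, then, the largest response stays level through changes in ring size, in the hetero atoms of the ring, in the halogen and in the presence of the hydrogen-bond donor, and no compound goes against this.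

Nothing shown accounts for this flat behaviour. Still open, as far as these compounds go, is whether the level holds when the aromatic ring at this position gives way to a non-aromatic group such as an amine, a piperidine or a longer alkyl chain, or to a ring bearing a carboxylic acid.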